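The source may report more compounds than this note shows. Statements on the series, on what has been measured and on what is new or still open speak of the compounds shown alone.

Compound 1 `O=C1/C(=C\c2ccccc2)C(c2ccccc2)Oc2ccccc21`: 27300 nM
Compound 2 `O=C1/C(=C/c2ccccc2)C(c2ccccc2)Oc2ccccc21`: 33300 nM
Compound 3 `O=C1/C(=C\c2ccccc2)C(c2ccccc2)Oc2ccc(O)cc21`: 7300 nM

In a functional assay on HL-60 cells (Homo sapiens) for cytotoxicity, read by MTT assay, with a stated time of 46 h (a higher number here means a weaker inhibitor, a lower number a stronger inhibitor), compound 1, at 27300 nM, stands level with compound 2, as a 1.2-fold higher number from compound 1 to compound 2 (0.09 log units; within the scatter) shows, and clear of compound 3, with a 3.7-fold lower number from compound 1 to compound 3 (0.57 log units; beyond the scatter). Compound 4 `O=C1/C(=C\c2ccc(Br)cc2)C(c2ccccc2)Oc2ccccc21` changes phenyl to 4-bromophenyl: bromo in place of hydrogen on an aromatic carbon, para to a large group. The double-bond step does not bear on this change. The closest guide is the hydroxy step to compound 3, a 3.7-fold lower number from compound 1 to compound 3 (0.57 log units; beyond the scatter), which involves another group at another place, so it is only a loose guide. A similarly modest fall is therefore expected, a 2.0-fold lower number from compound 1 to compound 4 (0.29 log units; within the scatter), in this assay. Compound 4 is estimated at 14000 nM, within a range of 5000 nM to 35000 nM.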

Compound 4, half-maximal inhibitory concentration: > 1000000 nM
Compound 4: no number, only a limit; the forecaster's own chance of this, stated with the estimate: 5%; middle value at least 71-fold (1.85 log units) from the limit.
By their numbers in this assay, from the lowest: compound 3; then compounds 1 and 2 (each within the scatter of the next). At a limit, above all of these: compound 4.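

In this assay, compound 4 gives > 1000000 nM, which is a limit of the assay and not a number. Going by these compounds alone, the only earlier substitution step went towards a lower number, a 3.7-fold lower number from compound 1 to compound 3 (0.57 log units; beyond the scatter), at another place and with another group. Bromo on an aromatic carbon, para to a large group, goes the other way, and by a large margin: an at least 36-fold higher number from compound 1 to compound 4 (1.56 log units; beyond the scatter).

From the compounds shown here alone, how fluoro, methoxy or an amine would read at this same place remains open. So does whether this step is specific to bromo or holds for any group there.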